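Swapping a Fluorinated Ring on a Weakly Active Series

The compounds below may be only part of what the source reports. "The series", "measured", "known", "first", "only" and "open" are said of these compounds alone.

Three compounds with a shared core were tested in a functional assay on HepG2 cells (Homo sapiens) for inhibition, read by MTT assay, with a stated time of 48 h; on this read-out higher numbers stand for weaker inhibition and lower numbers for stronger inhibition. Compound 1 `COc1cc(/C=N/Nc2nc(-c3ccc(Br)cc3)cs2)cc(Br)c1OC` gives 64600 nM. Compound 2 `COc1cc(/C=N/Nc2nc(-c3ccc(C(F)(F)F)cc3)cs2)c(Br)c(Br)c1OC` reaches only a limit of the assay, > 100000 nM, so no number is known for it. Compound 3 `COc1cc(/C=N/Nc2nc(-c3cc(C(F)(F)F)cc(C(F)(F)F)c3)cs2)cc(Br)c1OC` likewise stops at a limit, > 100000 nM. Compound 2 therefore stands at the limit of > 100000 nM in this assay, at which 2 of the 3 values shown sit, and only compound 1 offers a measured number in this series. Compound 4 `COc1cc(/C=N/Nc2nc(-c3ccc(F)c(F)c3)cs2)c(Br)c(Br)c1OC` differs from compound 2 in one place: 3,4-difluorophenyl in place of 4-(trifluoromethyl)phenyl on an aromatic carbon. Among the compounds with values here, no measured step of this kind exists here, so the change from compound 2 to compound 4 is expected to stay within the usual scatter, an at least 1.1-fold lower number from compound 2 to compound 4 (0.04 log units; that floor lies within the scatter). Compound 4 is accordingly estimated at 90000 nM, with a range from 40000 nM to 200000 nM.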

Compound 4, half-maximal inhibitory concentration: 49700 nM
The estimate for compound 4 lay 1.8-fold (0.26 log units) above the measured number; the measured number falls inside the stated range.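

Putting 3,4-difluorophenyl in place of 4-(trifluoromethyl)phenyl on this aromatic carbon brings an at least 2.0-fold lower number from compound 2 to compound 4 (0.30 log units; that floor lies within the scatter). A change at this position alone can therefore take a compound of this series from the assay limit to a measured number. The real size of the step stays unknown because compound 2 has only a limit and no number: the limit of > 100000 nM in this assay, at which 2 of the 4 values shown sit.

Going by these compounds, whether an unsubstituted phenyl or an amine at this position would shift the number stays open. The compounds shown also cannot tell whether each fluorine contributes.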